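Compound 3 to compound 4: methoxy to hydroxy

This account rests on a few compounds, and the source may have more. Where it says the series, first, only, none or still open, it means among the compounds named here.

Measured so far in a physicochemical assay, read by spectrophotometry, with a stated time of 30 min; a higher number here means a weaker inhibitor, a lower number a stronger inhibitor:
- compound 1 `O=C(CCc1nc2ccccc2c(=O)[nH]1)N/N=C/c1ccc([N+](=O)[O-])cc1` gives 328000000 nM
- compound 2 `O=C(CCc1nc2ccccc2c(=O)[nH]1)N/N=C/c1ccc(O)cc1` gives 238000000 nM
- compound 3 `COc1cc(/C=N/NC(=O)CCCc2nc3ccccc3c(=O)[nH]2)cc(OC)c1OC` gives 106000000 nM

Compound 3 holds the lowest of the three numbers, and its gap to each of the others lies beyond the scatter. Compound 4 `COc1cc(/C=N/NC(=O)CCCc2nc3ccccc3c(=O)[nH]2)cc(OC)c1O` differs from it by hydrogen in place of methyl on an oxygen on an aromatic ring, that is, methoxy to hydroxy. Among the compounds with values here, one measured step bears on this, and only loosely: a 1.4-fold lower number from compound 1 to compound 2 (0.14 log units; within the scatter), where hydroxy also enters, but in place of nitro. That step stays within the scatter, so only a small move towards a lower number is expected, not one clearly beyond the scatter. The expected step is a 1.3-fold lower number from compound 3 to compound 4 (0.12 log units; within the scatter) in this assay. For compound 4 the estimated value is 80000000 nM, with an expected range of 25000000 nM to 170000000 nM.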

Compound 4, half-maximal inhibitory concentration: 97000000 nM
For compound 4 the middle estimate is 1.2-fold (0.08 log units) below the measured one; measured number inside the range.
By their numbers in this assay, from the lowest: compounds 4 and 3 (each within the scatter of the next); then compounds 2 and 1 (each within the scatter of the next).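

In this assay hydrogen in place of methyl on an oxygen on an aromatic ring gives a 1.1-fold lower number from compound 3 to compound 4 (0.04 log units; within the scatter) and so stays within the scatter. Within the data shown here, this is the first direct reading of methoxy to hydroxy: at this place, the methyl can be lost without a step beyond the scatter. No measurement at hand gives a reason for this result.

Open, from the compounds shown here alone, is whether a larger group on this oxygen, such as ethoxy, or an amine in place of the hydroxy would also stay within the scatter. The same question stands for the remaining methoxy groups of compound 4.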